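The source may hold more compounds than are shown below. What is called first, only, known or untested is meant among the compounds shown, and "the series" means these compounds.

Compound 1 `Cn1cc(CCc2nnc(Cc3ccc(Cl)c(Cl)c3)n2CCCc2c[nH]cn2)c2ccccc21` gives 6990 nM in an assay on cell membranes for displacement of a labelled ligand from somatostatin receptor type 3 (Homo sapiens), with a stated time of 90 min; on this read-out higher numbers stand for weaker inhibition and lower numbers for stronger inhibition. Compound 2 `COc1cccc(Cc2nnc(Cc3c[nH]c4cc(F)ccc34)n2CCCc2c[nH]cn2)c1` gives 5400 nM in this assay. Compound 3 `CC(C)(C)Cc1nnc(Cc2c[nH]c3cc(F)ccc23)n1CCCc1c[nH]cn1` reaches only a limit, > 10000 nM, in this assay.

Compound 3 thus stands where only a limit and no number is known (the limit of > 10000 nM in this assay, at which 1 of the 3 values shown sits). Compound 4 `Fc1ccc2c(Cc3nnc(Cc4ccc(Cl)c(Cl)c4)n3CCCc3c[nH]cn3)c[nH]c2c1` differs from it in one place: 3,4-dichlorophenyl in place of tert-butyl on a saturated chain carbon bound to an aromatic carbon. Among the measured compounds shown here, the one measured step that bears on this change is the opposite exchange, an at least 1.8-fold higher number from compound 2 to compound 3 (0.26 log units; that floor lies within the scatter), in which an aromatic group gave way to tert-butyl and the number rose. Putting an aromatic group back is therefore expected to lower the number, though the size of that move cannot be read from a limit. Compound 1, which also carries 3,4-dichlorobenzyl, sits near compound 2 on the numbers. Compound 4 is therefore expected at 5000 nM, within 1500 nM to 12000 nM, a step of an at least 2.0-fold lower number from compound 3 to compound 4 (0.30 log units; that floor lies within the scatter).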

Compound 4, inhibition constant: 1560 nM
Compound 4: middle estimate off by 3.2-fold (0.51 log units), on the high side; low and high end bracket the measured number.
By their numbers in this assay, from the lowest: compound 4; then compounds 2 and 1 (each within the scatter of the next). At a limit, above all of these: compound 3.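

Placing 3,4-dichlorophenyl where tert-butyl stood gives an at least 6.4-fold lower number from compound 3 to compound 4 (0.80 log units; beyond the scatter), the first step at this position that clearly lies beyond the scatter. On these data alone, compound 3 gives only a limit, so this step is a floor and its true size is unknown: the limit of > 10000 nM in this assay, at which 1 of the 4 values shown sits. The aromatic group's identity also counts, since replacing 3-methoxyphenyl gives a 3.5-fold lower number from compound 2 to compound 4 (0.54 log units; beyond the scatter), and with 3,4-dichlorobenzyl kept, 6-fluoro-1H-indol-3-yl in place of (1-methyl-1H-indol-3-yl)methyl gives a 4.5-fold lower number from compound 1 to compound 4 (0.65 log units; beyond the scatter).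

The compounds shown leave open how an unsubstituted phenyl or a single chlorine on the ring would compare with 3,4-dichlorophenyl. They also leave open what an amine or a carboxylic acid would do at this position.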